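Heteroaryl swap on the cyclopropane of the biphenyl amides

A few compounds are considered here, and "the series" means these few. Any claim that something is new, unique, unknown or untested is made for them only; others in the source may bear on it.

Compound 2 `CC[C@H](C)[C@H](N)CN(C(=O)[C@@H]1C[C@H]1c1ccoc1)c1ccc(-c2ccccc2)cc1` gives 580 nM in a functional assay for agonist activity at G protein-coupled receptor 88 (Homo sapiens), read by HTRF and cAMP accumulation (on this read-out lower numbers stand for an effect already at smaller amounts and higher numbers for an effect only at larger amounts of compound), the lowest of the two numbers; compound 1 `CC[C@H](C)[C@H](N)CN(C(=O)[C@@H]1C[C@H]1c1c(F)cccc1F)c1ccc(-c2ccccc2)cc1` gives 11000 nM in this assay. Among the measured compounds shown here, the only measured step, a 19-fold lower number from compound 1 to compound 2 (1.28 log units; beyond the scatter), shows that the group on the saturated ring carbon moves the number strongly. Compound 3 `CC[C@H](C)[C@H](N)CN(C(=O)[C@@H]1C[C@H]1c1csc(C)n1)c1ccc(-c2ccccc2)cc1` carries 2-methyl-1,3-thiazol-4-yl in place of furan-3-yl on a saturated ring carbon. For the measured compounds named here, no measured step exchanges one five-membered heteroaromatic ring for another, so the size is uncertain. A step of a 1.6-fold higher number from compound 2 to compound 3 (0.19 log units; within the scatter) is expected. Compound 3 is estimated at 900 nM in this assay, with a range from 200 nM to 4000 nM.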

Compound 3, half-maximal effective concentration: 1500 nM
Beside the measured number, compound 3's estimate is 1.7-fold (0.22 log units) below it; measured number inside the range.
By their numbers in this assay, from the lowest: compound 2; then compound 3; then compound 1.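

At this position on the three-membered ring, the five-membered heteroaromatic rings are not interchangeable in this assay: 2-methyl-1,3-thiazol-4-yl in place of furan-3-yl gives a 2.6-fold higher number from compound 2 to compound 3 (0.41 log units; beyond the scatter), a modest loss. The advantage over 2,6-difluorophenyl nevertheless persists with this second heteroaromatic ring, with a 7.3-fold lower number from compound 1 to compound 3 (0.87 log units; beyond the scatter), so it is not confined to furan-3-yl. Nothing available gives a reason for either step.

The change alters both the ring and the methyl group at once, so their separate contributions remain unresolved. The unsubstituted 1,3-thiazol-4-yl group would separate them, while a pyridin-3-yl ring would test whether a six-membered heteroaromatic ring behaves like the five-membered ones or like 2,6-difluorophenyl.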